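This account rests on a few compounds, and the source may have more. Where it says the series, first, only, none or still open, it means among the compounds named here.

Compound 1 `O=S(=O)(NCCCCNCc1ccc(Br)cc1)c1cc(C(F)(F)F)cc(C(F)(F)F)c1` and compound 2 `COc1cccc(CNCCCNS(=O)(=O)c2cc(C(F)(F)F)cc(C(F)(F)F)c2)c1` share a core and differ only in the substituted benzyl group carried on the chain. In a functional assay on A2780 cells (Homo sapiens) for inhibition, read by MTT assay, with a stated time of 72 h (on this read-out higher numbers stand for weaker inhibition of growth and lower numbers for stronger inhibition of growth), compound 1 gives 2100 nM, and compound 2 gives 1600 nM. Going by the values given here, the one measured step, a 1.3-fold lower number from compound 1 to compound 2 (0.12 log units; within the scatter), shows that exchanging one substituted benzyl group for another left the read-out within the scatter, so these two numbers are best read as alike rather than ranked. Compound 3 `O=S(=O)(NCCCNCc1ccccc1Cl)c1cc(C(F)(F)F)cc(C(F)(F)F)c1` carries the change (2-chlorophenyl in place of 3-methoxyphenyl on a saturated chain carbon bound to an amine nitrogen). Among the compounds with values here, the only measured step that bears on this change, a 1.3-fold lower number from compound 1 to compound 2 (0.12 log units; within the scatter), also swapped one substituted benzyl for another and stayed within the scatter, so no shift beyond the scatter is expected here in either direction, a 1.1-fold higher number from compound 2 to compound 3 (0.03 log units; within the scatter). For compound 3 the estimate in this assay is therefore 1700 nM, with a range from 700 nM to 4000 nM.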

Compound 3, concentration for 50% growth inhibition: 9300 nM
Estimate against measurement, compound 3: 5.5-fold (0.74 log units) below; measured number above the stated range.
By their numbers in this assay, from the lowest: compounds 2 and 1 (each within the scatter of the next); then compound 3.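

The benzyl group on this amine is not as interchangeable as the first two compounds suggested: in this assay, 2-chlorophenyl in place of 3-methoxyphenyl gives a 5.8-fold higher number from compound 2 to compound 3 (0.76 log units; beyond the scatter) with a shift beyond the scatter. The comparison with the 4-bromobenzyl compound points the same way, showing a 4.4-fold higher number from compound 1 to compound 3 (0.65 log units; beyond the scatter) as growth inhibition weakens modestly. No measurement at hand explains this shift.

The compounds shown leave open whether the chlorine itself or its place on the ring accounts for the change. They also leave open how an unsubstituted benzyl or a pyridylmethyl group on the same amine would read in this assay on this core.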